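A few compounds are considered here, and "the series" means these few. Any claim that something is new, unique, unknown or untested is made for them only; others in the source may bear on it.

Compound 1 `CCS(=O)(=O)NCCOc1nc(C2CC2)nc(NS(=O)(=O)c2ccc(C(C)C)cn2)c1Oc1ccccc1OC`: 347 nM in a functional assay for inhibition of Endothelin-1 receptor (Rattus norvegicus); a higher number here means weaker binding, a lower number tighter binding
Compound 2 `CCCS(=O)(=O)NCCOc1nc(C2CC2)nc(NS(=O)(=O)c2ccc(C(C)C)cn2)c1Oc1ccccc1OC`: 288 nM
Compound 3 `CCS(=O)(=O)NCCCOc1nc(C2CC2)nc(NS(=O)(=O)c2ccc(C(C)C)cn2)c1Oc1ccccc1OC`: 105 nM

Compound 3 has the lowest number of the three. Its nearest neighbour is compound 2, with the step of a 2.7-fold lower number from compound 2 to compound 3 (0.44 log units; beyond the scatter), and compound 1 lies further away, with the step of a 3.3-fold lower number from compound 1 to compound 3 (0.52 log units; beyond the scatter). Compound 4 `COc1ccccc1Oc1c(NS(=O)(=O)c2ccc(C(C)C)cn2)nc(C2CC2)nc1OCCCNS(=O)(=O)c1cccs1` keeps the chain of compound 3 and changes only the group on the sulfonyl sulfur: thiophen-2-yl in place of ethyl on a sulfonyl sulfur. Going by the values given here, no measured step changes that group in the same way; the only step that touches the sulfonyl substituent at all is a 1.2-fold lower number from compound 1 to compound 2 (0.08 log units; within the scatter), a change that stayed within the scatter. On that basis a small step, if any, is expected for compound 4 in this assay, a 1.1-fold lower number from compound 3 to compound 4 (0.02 log units; within the scatter), and compound 4 is estimated at 100 nM, between 40 nM and 250 nM.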

Compound 4, dissociation constant: 120 nM
Beside the measured number, compound 4's estimate is 1.2-fold (0.08 log units) below it; low and high end bracket the measured number.
By their numbers in this assay, from the lowest: compounds 3 and 4 (each within the scatter of the next); then compounds 2 and 1 (each within the scatter of the next).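

On the sulfonyl sulfur, thiophen-2-yl in place of ethyl gives a 1.1-fold higher number from compound 3 to compound 4 (0.06 log units; within the scatter) in this assay, so this place on the chain of compound 3 accepts a five-membered aromatic ring without a step beyond the scatter. The thiophene sulfonamide also stays below both compounds with the shorter chain, with a 2.4-fold lower number from compound 2 to compound 4 (0.38 log units; beyond the scatter) and a 2.9-fold lower number from compound 1 to compound 4 (0.46 log units; beyond the scatter). Nothing given here explains these results. On these data alone, whether an amine, a carboxylic acid or a phenyl ring on the sulfonyl sulfur would behave alike stays open. So does the effect of thiophen-2-yl on the chain of compound 1.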